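Same aryl swap on a second core: compound 4 expected

This account rests on a few compounds, and the source may have more. Where it says the series, first, only, none or still open, it means among the compounds named here.

Compound 1 `Cc1cc(=O)n(-c2cccc(F)c2)nc1C(=O)Nc1ccc(Oc2ncnc3ccsc23)cc1` gives 6410 nM in a functional assay on MCF7 cells (Homo sapiens) for cytotoxicity, read by MTT assay, with a stated time of 72 h; on this read-out lower numbers stand for stronger inhibition and higher numbers for weaker inhibition. Compound 2 `Cc1ccc(-n2nc(C(=O)Nc3ccc(Oc4ncnc5ccsc45)cc3)c(C)cc2=O)cc1` differs from it by 4-methylphenyl in place of 3-fluorophenyl on an aromatic nitrogen and gives 23800 nM; the step is a 3.7-fold higher number from compound 1 to compound 2 (0.57 log units; beyond the scatter). Compound 3 `Cc1cc(=O)n(-c2cccc(F)c2)nc1C(=O)Nc1ccc(Oc2ncnc3sccc23)c(F)c1` sits on a different core; the difference between the two cores is not broken down here. In this assay compound 3 gives 17300 nM, within the scatter of compound 2 and beyond it from compound 1. Compound 4 `Cc1ccc(-n2nc(C(=O)Nc3ccc(Oc4ncnc5sccc45)c(F)c3)c(C)cc2=O)cc1` is not yet measured; it differs from compound 3 by 4-methylphenyl in place of 3-fluorophenyl on an aromatic nitrogen, the same change at the same place, so a step of similar size is expected. Within the data shown here, the step is expected to be a 3.2-fold higher number from compound 3 to compound 4 (0.50 log units; beyond the scatter), resting on the single earlier step of a 3.7-fold higher number from compound 1 to compound 2 (0.57 log units; beyond the scatter), with a wide range as only one pair supports it. In this assay compound 4 is therefore estimated at 55000 nM, expected between 20000 nM and 150000 nM.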

Compound 4, half-maximal inhibitory concentration: > 40000 nM
Compound 4: only a limit was reported (the forecaster's own chance of this, stated with the estimate: 25%); the middle value does not contradict the limit.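

For compound 4, the > 40000 nM reported in this assay is a limit of the assay and not a number. On the second core, 4-methylphenyl in place of 3-fluorophenyl on the aromatic nitrogen gives an at least 2.3-fold higher number from compound 3 to compound 4 (0.36 log units; beyond the scatter). The direction of the change therefore carries over between these two cores, but two pairs set no general rule and the size of the step on the second core remains unresolved: the same change on two cores in this assay, a 3.7-fold higher number (0.57 log units; beyond the scatter) from compound 1 to compound 2 and an at least 2.3-fold higher number (0.36 log units; beyond the scatter) from compound 3 to compound 4; the limit leaves it open whether they differ

The compounds shown leave open how an amine or a carboxylic acid on the aryl ring, in place of the fluorine or methyl group, would read out on either core. They also leave open how the two cores compare on their own.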